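The Thiazole Swap on an Inactive Orexin Ligand

A few compounds are considered here, and "the series" means these few. Any claim that something is new, unique, unknown or untested is made for them only; others in the source may bear on it.

Of the compounds shown here, two have been measured in an assay on CHO cells for displacement of a labelled ligand from Orexin/Hypocretin receptor type 1 (Homo sapiens), read by radioligand binding, with a stated time of 2 h; a lower number here means a stronger inhibitor, a higher number a weaker inhibitor. Compound 1 `O=S(=O)(c1cc(F)cc(F)c1)N1CCN(Cc2csc(-c3ccco3)n2)CC1` returns only the limit of this assay, > 100000 nM, not a number. Compound 2 `O=C(c1ccc(OCc2cn3ccccc3n2)cc1)N1CCC[C@@H]1c1ccc2c(c1)OCCO2` likewise reaches only a limit in this assay, > 100000 nM. Among the compounds with values here, compound 2 therefore stands at the limit rather than at a value, and both measured compounds sit there, as the limit of > 100000 nM in this assay, at which 2 of the 2 values shown sit, records, so no step between measured compounds can be read. Compound 3 `Cc1nc(COc2ccc(C(=O)N3CCC[C@@H]3c3ccc4c(c3)OCCO4)cc2)cs1` is not yet measured and differs from compound 2 in one place: a group of 6 heavy atoms (4 carbon, 1 nitrogen, 1 sulfur; one five-membered aromatic ring with 2 hetero atoms) in place of a group of 9 heavy atoms (7 carbon, 2 nitrogen; one five-membered aromatic ring with 2 hetero atoms, one six-membered aromatic ring with 1 hetero atom), on a saturated chain carbon bound to an oxygen on an aromatic ring. With nothing measured to lean on beyond two limits, the author expects no change beyond the scatter. The expected step of a number no higher from compound 2 to compound 3 (the limit leaves the size open) is essentially flat, and a further limit rather than a number is the likelier outcome. Compound 3 is expected to give 100000 nM, within a range from 20000 nM to 300000 nM.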

Compound 3, half-maximal inhibitory concentration: > 100000 nM
Compound 3: a limit, no number; the forecaster's own chance of this, stated with the estimate: 75%; the middle value sits exactly at the limit.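

Compound 2 and compound 3 both return only a limit, not a number, so no step between them can be read: the limit of > 100000 nM in this assay, at which 3 of the 3 values shown sit.

The compounds shown leave open whether any group at this place, or any other change to the shared core, would give a measurable value.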